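The compounds below may be only part of what the source reports. "The series", "measured", "known", "first", "only" and "open" are said of these compounds alone.

Compound 2 `COc1ccc(NC(=O)Oc2cc(=O)n(CCCO)c3c2CC(C/C=C(\C)CCC=C(C)C)C(C)(C)C3)cc1` gives 64.1% in a functional assay on PANC-1 cells (Homo sapiens) for inhibition, read by MTT assay, with a stated time of 24 h, tested at 10 uM (on this read-out higher numbers stand for more inhibition at the one concentration tested (going by the name of the read-out) and lower numbers for less inhibition), and stands alongside compound 1 `CC(C)=CCC/C(C)=C/CC1Cc2c(OCCCNC(=O)c3ccco3)cc(=O)n(CCCO)c2CC1(C)C`, which gives 69.5%, the two within the scatter, as the step of a number 5.4 percentage points lower from compound 1 to compound 2 (within the scatter) shows. Compound 3 `CC(C)=CCC/C(C)=C/CC1Cc2c(OC(=O)Nc3ccc(Cl)c(Cl)c3)cc(=O)n(CCCO)c2CC1(C)C` carries 3,4-dichlorophenyl in place of 4-methoxyphenyl on an amide-type nitrogen. Among the measured compounds shown here, no measured step varies the group on the amide-type nitrogen, so the one step on record, a number 5.4 percentage points lower from compound 1 to compound 2 (within the scatter), bears on it only loosely, and no step beyond the scatter is expected in this assay. Compound 3 is therefore estimated at 62%, within 50% to 74%, an expected step of a number 2.1 percentage points lower from compound 2 to compound 3 (within the scatter).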

Compound 3, a percentage reported as inhibition, at one concentration (the size of the read-out at that concentration, not a potency): 20%
Estimate against measurement, compound 3: 42 percentage points above; the measured number lies below the stated range.
By their numbers in this assay, from the lowest: compound 3; then compounds 2 and 1 (each within the scatter of the next).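

In this assay, among the compounds shown here, the group on the amide-type nitrogen proves decisive: 3,4-dichlorophenyl in place of 4-methoxyphenyl gives a number 44.1 percentage points lower from compound 2 to compound 3 (beyond the scatter) and is the first change beyond the scatter. Compound 3 also stands apart from compound 1, with a number 49.5 percentage points lower from compound 1 to compound 3 (beyond the scatter) on record for the change on the oxygen on an aromatic ring. Since compound 2 carries the same carbamoyl link, that link alone does not account for the loss.

From the compounds shown here alone, whether a phenyl with a single chlorine or an unsubstituted phenyl follows compound 2 or compound 3 remains open. No measurement on hand explains the drop.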